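Adding a methanesulfonamide to the biphenyl tail of compound 1

The source may hold more compounds than are shown below. What is called first, only, known or untested is meant among the compounds shown, and "the series" means these compounds.

Compound 1 `O=C(O)CC/C=C\CO[C@H]1C(OCc2ccc(-c3ccccc3)cc2)CC[C@@H]1N1CCCCCC1` is the starting point. In a functional assay for antagonist activity at thromboxane A2 receptor (Rattus norvegicus) (a higher number here means weaker binding, a lower number tighter binding), compound 1 gives 25.1 nM. Compound 3 `O=C(O)CC/C=C\CO[C@H]1[C@@H](OCc2ccc(-c3ccccc3)cc2)CC[C@@H]1N1CCCCCC1` differs only in that one ring stereocentre is drawn with a configuration, and compound 3 gives 39.8 nM; the step of a 1.6-fold higher number from compound 1 to compound 3 (0.20 log units; within the scatter) stays within the scatter, so the two numbers cannot be told apart. Compound 2 `O=C(O)CC/C=C\CO[C@H]1C(OCc2ccc(-c3ccccc3)cc2)CC[C@@H]1N1CCCCC1` has a smaller amine ring and has been measured twice, giving 794 nM; 63.1 nM (2 entries); the spread between these two entries the several entries of compound 2 in this assay, 794 nM; 63.1 nM (2 entries) means no single number can be assigned to compound 2.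

Compound 4 `CS(=O)(=O)Nc1cccc(-c2ccc(COC3CC[C@H](N4CCCCCC4)[C@H]3OC/C=C\CCC(=O)O)cc2)c1` is not yet measured. It differs from compound 1 by methanesulfonamido in place of hydrogen on an aromatic carbon. Among the compounds with values here, none of the measured steps touches this outer aromatic ring: the one step that can be sized, between compound 1 and compound 3, concerns a ring stereocentre, and compound 2 concerns the amine ring. There is therefore no measured basis for the direction of this change. Compound 4 is expected to give about 20 nM, with a range from 4 nM to 100 nM. The expected step of a 1.3-fold lower number from compound 1 to compound 4 (0.10 log units; within the scatter) is best taken as none beyond the scatter, with a wide range to reflect the lack of evidence.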

Compound 4, dissociation constant: 50.1 nM
The estimate for compound 4 lay 2.5-fold (0.40 log units) below the measured number; the range from low to high includes it.
By their numbers in this assay, from the lowest: compounds 1, 3 and 4 (each within the scatter of the next).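

Until now, the measured differences concerned only a ring stereocentre and the size of the amine ring, so the outer aromatic ring of the biphenyl tail is new ground. In this assay, methanesulfonamido in place of hydrogen on that ring, meta to a large group, gives a 2.0-fold higher number from compound 1 to compound 4 (0.30 log units; within the scatter), so this position takes a much larger group than hydrogen with no difference that can be told from the scatter. Nothing shown here bears on why the number stays within the scatter with this group in place.

On these data alone, a single group at a single place says little about its neighbours, so it remains open whether acetamido or a carboxylic acid on the same aromatic carbon, or methanesulfonamido elsewhere on the outer ring, would also stay within the scatter of compound 1. As far as these compounds go, it is also open whether the same addition would behave alike on compound 3, with its defined ring stereocentre, or on compound 2, with its smaller amine ring and its widely separated entries.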